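From a propanoyl group to a methyl group

The compounds below may be only part of what the source reports. "The series", "measured", "known", "first", "only" and "open" are said of these compounds alone.

compound 1 (`C=C[C@@](C)(/C=C/c1ccc(OC(=O)CC)cc1)CCC=C(C)C`), measured at (42%)
compound 2 (`C=C[C@@](C)(/C=C/c1ccc(OC(=O)CCCCCCCCC)cc1)CCC=C(C)C`), measured at (48%)

Both compounds were tested in a functional assay on A549 cells (Homo sapiens) for inhibition, with a stated time of 48 h, tested at 50 uM (on this read-out lower numbers stand for less inhibition of growth and higher numbers for more inhibition of growth at the one concentration tested), and they stand close together. Within the data shown here, the only measured step is a number 6 percentage points higher from compound 1 to compound 2 (within the scatter) and it gives compound 1 no clearly separate place on these numbers.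

The next compound is compound 3 (`C=C[C@@](C)(/C=C/c1ccc(OC)cc1)CCC=C(C)C`), which has not yet been measured. The structural change from the core of compound 1 is methyl in place of propanoyl on an oxygen on an aromatic ring and it amounts to methyl in place of propanoyl on an oxygen on an aromatic ring, or propanoyloxy to methoxy. Among the measured compounds shown here, only one measured step bears on this, and only loosely. That step, a number 6 percentage points higher from compound 1 to compound 2 (within the scatter) in size, was heptyl in place of hydrogen on a saturated chain carbon, and the propanoyl carbonyl stayed in place. For the measured compounds named here, no measured compound shows what happens when the propanoyl leaves altogether. Going by that one small step, no shift beyond the scatter is expected in this assay although the uncertainty is wide. The estimated change is a number 2 percentage points lower from compound 1 to compound 3 (within the scatter) on this reasoning. For compound 3 the estimated value is 40% with an expected range of 24% to 56% in this read-out.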

Compound 3, percent growth inhibition at one concentration: 12%
The estimate for compound 3 lay 28 percentage points above the measured number; measured number outside the range, below it.
By their numbers in this assay, from the lowest: compound 3; then compounds 1 and 2 (each within the scatter of the next).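

Among these compounds, the change of methyl in place of propanoyl on an oxygen on an aromatic ring is the first one here to move this assay beyond the scatter, with a number 30 percentage points lower from compound 1 to compound 3 (beyond the scatter). The earlier step, a number 6 percentage points higher from compound 1 to compound 2 (within the scatter), lengthened the chain and kept the carbonyl, and it gave no separation, so the two esters could not show that this oxygen substituent matters to the read-out; the pair of compound 1 and compound 3 shows that it does, and that propanoyloxy gives more inhibition of growth than methoxy on the shared core. Nothing available explains this difference.

The compounds shown leave open whether the carbonyl or the chain attached to it accounts for the difference, as propanoyloxy to methoxy removes both together; an acetyl group or an ethyl group on the same oxygen, or a free hydroxyl in place of the propanoyloxy, would separate the two. They also leave open whether the difference holds at other concentrations or in other cell lines, as all of these numbers come from a single concentration in one cell line.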